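Hydroxymethyl gives way to ethoxycarbonyl in compound 1

The source may hold more compounds than are shown below. What is called first, only, known or untested is meant among the compounds shown, and "the series" means these compounds.

In a functional assay on A549 cells (Homo sapiens) for cytotoxicity, read by MTT assay, with a stated time of 48 h (on this read-out higher numbers stand for weaker inhibition and lower numbers for stronger inhibition), compound 1 `COc1cc([C@@H]2C[C@@]2(CO)C(=O)Nc2ccccc2)cc(OC)c1OC` gives 43200 nM. This is the higher of the two actual numbers available, and compound 3 `COc1cc([C@@H]2C[C@@]2(CO)C(=O)Nc2ccccc2Cl)cc(OC)c1OC` gives the lower, 11400 nM. Compound 2 `COc1cc([C@H]2C[C@@]2(CO)C(=O)Nc2ccccc2)cc(OC)c1OC` has only a limit, > 100000 nM.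

Two measured steps start from compound 1. One is an at least 2.3-fold higher number from compound 1 to compound 2 (0.36 log units; beyond the scatter), and it goes with the fact that compounds 1 and 2 differ only in the configuration as drawn. The other is a 3.8-fold lower number from compound 1 to compound 3 (0.58 log units; beyond the scatter), with chloro in place of hydrogen on an aromatic carbon.

Compound 4 `CCOC(=O)[C@@]1(C(=O)Nc2ccccc2)C[C@H]1c1cc(OC)c(OC)c(OC)c1` has not yet been measured. It departs from compound 1 through (ethoxycarbonyl in place of hydroxymethyl on a saturated ring carbon), with ethoxycarbonyl in place of hydroxymethyl on a saturated ring carbon. Neither measured step alters that group, so they bear on this exchange only indirectly and give it no direction. Taking a 3.8-fold lower number from compound 1 to compound 3 (0.58 log units; beyond the scatter) as the only size backed by two actual numbers, a change of about that order could occur either way, but the central expectation is no step beyond the scatter.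

The estimated change is a 1.2-fold higher number from compound 1 to compound 4 (0.06 log units; within the scatter). For compound 4 the expected value is 50000 nM, with an estimated range of 15000 nM to 130000 nM.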

Compound 4, half-maximal inhibitory concentration: 65900 nM
The estimate for compound 4 lay 1.3-fold (0.12 log units) below the measured number; measured number inside the range.
By their numbers in this assay, from the lowest: compound 3; then compounds 1 and 4 (each within the scatter of the next). At a limit, above all of these: compound 2.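

In this assay the exchange of hydroxymethyl for ethoxycarbonyl on a saturated ring carbon gives a 1.5-fold higher number from compound 1 to compound 4 (0.18 log units; within the scatter) and so stays within the scatter, whereas both earlier steps from compound 1 lay beyond it. For the compounds shown here, this is the first sight of a change at this position itself, and in this single pair a swap from hydroxymethyl, with 2 heavy atoms and 1 hydrogen-bond donor, to ethoxycarbonyl, with 5 heavy atoms and 0 hydrogen-bond donors, does not move the number beyond the scatter. Nothing in the information available bears on the reason for this result.

The compounds shown leave open whether the same exchange would remain this small on the chloro-bearing compound 3 or on compound 2, which differs from compound 1 in its drawn configuration. They also leave open how a carboxylic acid, an aminomethyl group or a longer ester chain would read at this place on the three-membered ring.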